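Phenyl for Dichlorophenyl: Expected Loss of Antiproliferative Activity

The source may hold more compounds than are shown below. What is called first, only, known or untested is meant among the compounds shown, and "the series" means these compounds.

Compound 1 `Cc1nc(-c2ccc(Cl)cc2)sc1C(=O)CSc1nc(-c2ccccc2)c(C#N)c(=O)[nH]1`: 41.6%
Compound 2 `Cc1nc(-c2ccc(Cl)cc2)sc1C(=O)CSc1nc(-c2ccc(Cl)c(Cl)c2)c(C#N)c(=O)[nH]1`: 93.9%
Compound 3 `COc1ccc(-c2nc(C)c(C(=O)CSc3nc(-c4ccc(Cl)c(Cl)c4)c(C#N)c(=O)[nH]3)s2)cc1`: 78.4%

In a functional assay on U-87MG ATCC cells for antiproliferative activity against U-87 MG (Homo sapiens), read by MTT assay, with a stated time of 48 h, tested at 50 uM (on this read-out higher numbers stand for a weaker effect at the one concentration tested and lower numbers for a stronger effect), compound 2 gives 93.9%, the highest of the three numbers. The change phenyl in place of 3,4-dichlorophenyl on an aromatic carbon gave the step of a number 52.3 percentage points lower from compound 2 to compound 1 (beyond the scatter). The cores of compound 2 and compound 3 differ by methoxy in place of chloro on an aromatic carbon, and that change gave the step of a number 15.5 percentage points lower from compound 2 to compound 3 (beyond the scatter).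

Compound 4 `COc1ccc(-c2nc(C)c(C(=O)CSc3nc(-c4ccccc4)c(C#N)c(=O)[nH]3)s2)cc1` has not been measured. It differs from compound 3 by phenyl in place of 3,4-dichlorophenyl on an aromatic carbon, and the surroundings of that place are word for word the same as for the change from compound 2 to compound 1, so this is the same change made on the other core. The earlier step was large, so a large drop is expected here too, estimated as a number 48.4 percentage points lower from compound 3 to compound 4 (beyond the scatter) in this assay, resting on compound 3 at 78.4% and on the step of a number 52.3 percentage points lower from compound 2 to compound 1 (beyond the scatter). For the measured compounds named here, only one earlier example of the change exists, so the size is uncertain. Compound 4 is therefore expected to give about 30% in this assay, estimated between 14% and 50%.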

Compound 4, a percentage reported as activity, at one concentration (the size of the read-out at that concentration, not a potency): 72.5%
Estimate against measurement, compound 4: 42.5 percentage points below, and the stated range ends below it.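

In this assay, phenyl in place of 3,4-dichlorophenyl on the core of compound 3 gave a number 5.9 percentage points lower from compound 3 to compound 4 (within the scatter), so the large step seen on the first core did not carry over to this one: the same change on two cores in this assay, a number 52.3 percentage points lower (beyond the scatter) from compound 2 to compound 1 and a number 5.9 percentage points lower (within the scatter) from compound 3 to compound 4, 46.4 percentage points apart, beyond the scatter of two such steps. Read the other way around, methoxy in place of chloro gave a number 30.9 percentage points higher from compound 1 to compound 4 (beyond the scatter), which runs opposite to the earlier step for the same change: the same change on two cores in this assay, a number 15.5 percentage points lower (beyond the scatter) from compound 2 to compound 3 and a number 30.9 percentage points higher (beyond the scatter) from compound 1 to compound 4, 46.4 percentage points apart, beyond the scatter of two such steps. For the compounds shown here, in these four compounds, then, the result of each change depends on what sits at the other place, but this does not show why, and each core offers only a single example read at one concentration.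

On these data alone, it remains open whether this dependence extends beyond phenyl and 3,4-dichlorophenyl at one place and chloro and methoxy at the other. As far as these compounds go, how an amine, a carboxylic acid or a longer chain would behave at either place also stays unknown, as does whether these differences would hold at other concentrations.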